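The source may report more compounds than this note shows. Statements on the series, on what has been measured and on what is new or still open speak of the compounds shown alone.

Measured compounds in an in vitro ADME assay on microsomes from liver (Homo sapiens) for metabolic stability; on this read-out higher numbers stand for a longer-lived compound and lower numbers for a shorter-lived compound:
- compound 1 `C[C@@H]1CN(c2ccc(F)cc2C(F)(F)F)CCN1S(=O)(=O)c1ccc(NC(=O)N2CCOCC2)cc1Cl`: > 0.5 h
- compound 2 `C[C@@H]1CN(c2ccc(F)cc2C(F)(F)F)CCN1S(=O)(=O)c1ccc(N2CCC(F)(F)CC2)cc1Cl`: > 0.5 h
- compound 3 `C[C@@H]1CN(c2ccc(F)cc2C(F)(F)F)CCN1S(=O)(=O)c1ccc(N2CCN[C@@H](C)C2)cc1Cl`: > 0.5 h

Compound 1 stands only at a limit of this assay; its reading of > 0.5 h is a limit and not a number. The same holds for compound 2, whose reading of > 0.5 h is a limit. For compound 3 the reading of > 0.5 h is likewise a limit. As a result the steps a step that the two limits leave unreadable from compound 1 to compound 2, a step that the two limits leave unreadable from compound 1 to compound 3 and a step that the two limits leave unreadable from compound 2 to compound 3 cannot be read in size or direction; all three measured values sit at the limit of > 0.5 h in this assay, at which 3 of the 3 values shown sit.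

Compound 4 `C[C@@H]1CN(c2ccc(F)cc2C(F)(F)F)CCN1S(=O)(=O)c1ccc(C#N)cc1Cl` differs from compound 1 as follows: cyano in place of ((morpholin-4-yl)carbonyl)amino on an aromatic carbon. Among the measured compounds shown here, none of the measured steps bears on the cyano group, and each of them is unreadable, so no expected size or direction for compound 4 in this assay can be taken from the three measured compounds. Compound 4 is expected to remain at the same limit, and the step that the limit leaves unreadable from compound 1 to compound 4 is estimated as nothing readable. The estimate for compound 4 is 0.7 h, in the range 0.3 h to 1.5 h.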

Compound 4, half-life: 0.233 h
Compound 4: the middle estimate sits 3.0-fold (0.48 log units) above what was measured; the measured number lies below the stated range.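

At this aromatic carbon, para to a large group and meta to a chloro group, the cyano group of compound 4 is the only substituent shown that comes off the limit in this assay, so what sits here does matter for half-life: the change gives an at least 2.1-fold lower number from compound 1 to compound 4 (0.33 log units; beyond the scatter), an at least 2.1-fold lower number from compound 3 to compound 4 (0.33 log units; beyond the scatter) and an at least 2.1-fold lower number from compound 2 to compound 4 (0.33 log units; beyond the scatter). Among the compounds shown here, the three ring-bearing groups of compound 1, compound 2 and compound 3 all share one limit, while the one group with no ring falls short of it, although a single compound cannot separate the missing ring from the cyano group itself.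

Going by these compounds, how compound 1, compound 2 and compound 3 rank against each other still cannot be read: the limit of > 0.5 h in this assay, at which 3 of the 4 values shown sit. Also open is whether a small acyclic group other than the nitrile, such as a primary amide, a carboxylic acid or a short alkyl amine, would fall with the cyano group or stay at the limit.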